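Swapping the whole aromatic ring on the core of compound 1

The compounds below may be only part of what the source reports. "The series", "measured", "known", "first", "only" and "open" are said of these compounds alone.

Measured compounds:
compound 1, `Cc1ccsc1CN[C@@H]1C[C@H]2C[C@@H]([C@H]1C)C2(C)C`, 10000 nM
compound 2, `C=Cc1ccsc1CN[C@@H]1C[C@H]2C[C@@H]([C@H]1C)C2(C)C`, 50000 nM
compound 3, `C[C@H]1[C@H](NCc2sccc2C2CC2)C[C@H]2C[C@@H]1C2(C)C`, 25000 nM

These three compounds were tested in an ADME assay on MDCK cells (Canis lupus familiaris) for cytotoxicity, read by microscopy, with a stated time of 48 h; on this read-out higher numbers stand for lower toxicity in this test and lower numbers for higher toxicity in this test. Compound 1 gives the lowest number of the three, so on this read-out it is the most toxic of the set. Both of its neighbours were made by changing only the methyl on the aromatic ring: vinyl in place of methyl gave a 5.0-fold higher number from compound 1 to compound 2 (0.70 log units; beyond the scatter), and cyclopropyl in place of methyl gave a 2.5-fold higher number from compound 1 to compound 3 (0.40 log units; beyond the scatter). Between compound 2 and compound 3 the difference was a 2.0-fold lower number from compound 2 to compound 3 (0.30 log units; within the scatter).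

Compound 4, `C[C@H]1[C@H](NCc2cncnc2)C[C@H]2C[C@@H]1C2(C)C`, has not yet been measured. Compared with compound 1 the change is pyrimidin-5-yl in place of 3-methylthiophen-2-yl on a saturated chain carbon bound to an amine nitrogen. For the measured compounds named here, no measured step exchanges the ring itself; the two steps seen so far only alter a substituent on that ring, and both moved the number upward from compound 1 by a modest amount. On that slim basis compound 4 is expected to land somewhere above compound 1, with wide uncertainty, so the estimated step is a 2.0-fold higher number from compound 1 to compound 4 (0.30 log units; within the scatter). The estimate for compound 4 in this assay is therefore 20000 nM, with a range from 5000 nM to 80000 nM.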

Compound 4, minimum cytotoxic concentration: > 100000 nM
Compound 4 ended at the assay's limit; the forecaster's own chance of this, stated with the estimate: 15%; middle value at least 5.0-fold (0.69 log units) from the limit.
By their numbers in this assay, from the lowest: compound 1; then compounds 3 and 2 (each within the scatter of the next). At a limit, above all of these: compound 4.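

The earlier compounds shown here only altered a substituent on the ring, whereas compound 4 replaces the ring itself, and in this assay pyrimidin-5-yl in place of 3-methylthiophen-2-yl gave an at least 10-fold higher number from compound 1 to compound 4 (1.00 log units; beyond the scatter), which on this read-out means lower toxicity in this test. The result for compound 4, > 100000 nM, is a limit of the assay and not a number, so only its lower bound is known: the limit of > 100000 nM in this assay, at which 1 of the 4 values shown sits. The two groups have the same number of heavy atoms, so this step comes with a change in ring size and hetero atoms, not in the count of heavy atoms, and this position on the saturated chain carbon bound to an amine nitrogen can carry a large shift in the read-out.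

This single exchange changes the ring size, the hetero atoms and the methyl all at once, so the compounds shown cannot say which of these accounts for the step. A phenyl or pyridin-3-yl group in the same place, or a pyrimidin-5-yl ring bearing a methyl, would help to separate these contributions.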